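Replacing Cyclopropylmethoxy with Chloro: What Permeability to Expect

The compounds below may be only part of what the source reports. "The series", "measured", "known", "first", "only" and "open" are said of these compounds alone.

Going by the values given here, compound 3 `O=C(O)CCn1c(=O)oc2cc(OCC3CC3)c(Cl)cc21` is the only member of this small set with a number rather than a limit: in a physicochemical assay for permeability, using PAMPA (on this read-out lower numbers stand for lower permeability and higher numbers for higher permeability), compound 3 gives 19 nm/s. Compound 1 `CC(C)Cc1cc2oc(=O)n(CCC(=O)O)c2cc1Cl` reaches only a limit of this assay, < 10 nm/s. Compound 2 `CCOc1cc2oc(=O)n(CCC(=O)O)c2cc1Cl` likewise sits at a limit, < 10 nm/s. Two of the three values share (the limit of < 10 nm/s in this assay, at which 2 of the 3 values shown sit). The measured steps are an at least 1.9-fold higher number from compound 1 to compound 3 (0.27 log units; that floor lies within the scatter) and an at least 1.9-fold higher number from compound 2 to compound 3 (0.27 log units; that floor lies within the scatter), while a step that the two limits leave unreadable from compound 1 to compound 2. Compound 4 `O=C(O)CCn1c(=O)oc2cc(Cl)c(Cl)cc21` differs from compound 3 by chloro in place of cyclopropylmethoxy on an aromatic carbon. Among the compounds with values here, no measured step exchanges an alkoxy for chloro, so the precedent is indirect. Both readable steps run toward compound 3, and compound 4 is expected to fall back toward the limit. Compound 4 is estimated at 10 nm/s, with a range from 3 nm/s to 30 nm/s, which would mean an expected 1.9-fold lower number from compound 3 to compound 4 (0.28 log units; within the scatter).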

Compound 4, apparent permeability: 24 nm/s
For compound 4 the middle estimate is 2.4-fold (0.38 log units) below the measured one; the measured number falls inside the stated range.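

In this assay, chloro in place of cyclopropylmethoxy gives a 1.3-fold higher number from compound 3 to compound 4 (0.10 log units; within the scatter), so the 5 heavy atoms of cyclopropylmethoxy are not needed at this position for a readable number. Chloro in place of ethoxy gives an at least 2.4-fold higher number from compound 2 to compound 4 (0.38 log units; beyond the scatter), and chloro in place of isobutyl gives an at least 2.4-fold higher number from compound 1 to compound 4 (0.38 log units; beyond the scatter); these are the first steps in the set that lie beyond the scatter. Both are floors rather than full sizes: the limit of < 10 nm/s in this assay, at which 2 of the 4 values shown sit.

The compounds shown leave open what bromo or an amine would give at this position in this assay. On these data alone, how large those two floor steps really are also stays open.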